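A few compounds are considered here, and "the series" means these few. Any claim that something is new, unique, unknown or untested is made for them only; others in the source may bear on it.

Measured compounds and their numbers in an assay on CHO cells for agonist activity at Neuronal acetylcholine receptor; alpha3/beta4 (Homo sapiens), read by FLIPR and calcium flux; a lower number here means that less compound is needed, a higher number that more compound is needed for the effect:
compound 1 `C[C@H]1C[C@@H]1C(=O)N1CC2CNCC2C1`: 34000 nM
compound 2 `CCC(=O)N1CC2CNCC2C1`: 18000 nM
compound 3 `O=C(C1CC1)[C@H]1C[C@H]2CNC[C@H]2C1`: 930 nM

Compound 3 stands at the lowest of the three numbers; its nearest neighbour, compound 2, lies beyond the scatter from it, and compound 1 lies further off still. Compound 4 `COC(=O)[C@H]1C[C@H]2CNC[C@H]2C1` keeps the core of compound 3 and differs from it in one place only: methoxy in place of cyclopropyl on a carbonyl carbon.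

Within the data shown here, only one measured step bears on a change at a carbonyl carbon, a 1.9-fold lower number from compound 1 to compound 2 (0.28 log units; within the scatter), and that step sits on a different core and stays within the scatter. Among the measured compounds shown here, no step on the core of compound 3 has been measured, and no measured compound carries a methoxy on the carbonyl carbon. For the measured compounds named here, the expectation for compound 4 therefore rests on the one small step seen at a carbonyl carbon, and the step from compound 3 to compound 4 is expected to be modest, a 2.2-fold higher number from compound 3 to compound 4 (0.33 log units; beyond the scatter), in the direction of a somewhat higher number. Compound 4 is accordingly estimated at 2000 nM in this assay, with a range from 600 nM to 8000 nM.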

Compound 4, half-maximal effective concentration: 14000 nM
The estimate for compound 4 lay 7.0-fold (0.85 log units) below the measured number; measured number above the stated range.
By their numbers in this assay, from the lowest: compound 3; then compounds 4, 2 and 1 (each within the scatter of the next, the first and the last beyond it).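

In this assay the carbonyl carbon on the core of compound 3 proves a sensitive place: methoxy in place of cyclopropyl gives a 15-fold higher number from compound 3 to compound 4 (1.18 log units; beyond the scatter) and thus a large step. Among these compounds, the only earlier change at a carbonyl carbon, a 1.9-fold lower number from compound 1 to compound 2 (0.28 log units; within the scatter) on a different core, stayed within the scatter, so that small step does not carry over to this core. Nothing available on these compounds accounts for the size of the new step.

On these data alone, it remains open whether the step follows from the loss of the cyclopropyl ring or from the entry of the methoxy oxygen; an ethyl or an amine on the same carbonyl carbon of this core would help separate the two. As far as these compounds go, whether the same exchange gives a step of this size on the core of compound 1 also remains open.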